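The source may hold more compounds than are shown below. What is called first, only, known or untested is meant among the compounds shown, and "the series" means these compounds.

The series is followed in an ADME assay on L929 cells (Mus musculus) for cytotoxicity, read by resazurin assay, with a stated time of 72 h; a higher number here means a weaker inhibitor, a lower number a stronger inhibitor. Compound 1 `OB1OCc2ccc(-n3cc(Sc4ccc(O)cc4)c4ccccc43)cc21` is one of the two measured compounds. In this assay compound 1 gives > 10 ug/mL, which is a limit of the assay and not a number. Compound 2 `O=C(c1cccc(Cl)c1)c1ccn(-c2ccc3c(c2)B(O)OC3)c1` is the starting point of the step followed here. In this assay compound 2 gives > 10 ug/mL, again a limit rather than a number. Compound 2 thus stands where every measured value of the series stands: the limit of > 10 ug/mL in this assay, at which 2 of the 2 values shown sit. Within the data shown here, no step between two measured compounds is available, so nothing measured says how a change on the carbonyl carbon moves the read-out.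

Compound 3 `NCCCC(=O)c1ccn(-c2ccc3c(c2)B(O)OC3)c1` is the unmeasured compound. It differs from compound 2 in one place: 3-aminopropyl in place of 3-chlorophenyl on a carbonyl carbon. The step from compound 2 to compound 3 is expected to be small, a step that the limit leaves unreadable from compound 2 to compound 3, with no direction beyond the scatter. Among the measured compounds shown here, the limit at which compound 1 and compound 2 both sit the limit of > 10 ug/mL in this assay, at which 2 of the 2 values shown sit, is the only guide. Compound 3 is expected to give 20 ug/mL in this assay, in a range from 8 ug/mL to 60 ug/mL, and is likely to be reported once more as a limit.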

Compound 3, half-maximal inhibitory concentration: > 10 ug/mL
Compound 3 ended at the assay's limit; the forecaster's own chance of this, stated with the estimate: 75%; the middle value lies beyond the limit too.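

In this assay compound 3 gives > 10 ug/mL as a limit of the assay and not a number. Among these compounds, compound 2 sits at a limit as well, so no step from compound 2 to compound 3 can be read. The compounds shown leave open what actual value any of them would give, since all remain at the limit: the limit of > 10 ug/mL in this assay, at which 3 of the 3 values shown sit.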